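The compounds below may be only part of what the source reports. "The series", "measured", "known", "first", "only" and "open" are said of these compounds alone.

Measured so far in an assay on isolated protein for inhibition of mitogen-activated protein kinase kinase kinase 14 (Homo sapiens), read by fluorescence polarization, with a stated time of 2 h; on this read-out higher numbers stand for weaker inhibition and lower numbers for stronger inhibition:
- compound 1 `CC(C)(O)C#Cc1ccc2c(c1)-c1nc(C(N)=O)cn1C1CC2C1`: 20 nM
- compound 2 `CC(C)(O)C#Cc1cc2c(cc1F)C1CC(C1)n1cc(C(N)=O)nc1-2`: 2.9 nM

Going by the values given here, compound 2 holds the lower of the two numbers in this assay; the only measured step, a 6.9-fold lower number from compound 1 to compound 2 (0.84 log units; beyond the scatter), is a fluoro in place of hydrogen on an aromatic carbon, and it lies beyond the scatter.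

Compound 3 `Cc1cc([C@](C)(O)C#Cc2cc3c(cc2F)C2CC(C2)n2cc(C(N)=O)nc2-3)no1` differs from compound 2 at the other end of the molecule: 1-hydroxy-1-(5-methyl-1,2-oxazol-3-yl)ethyl in place of 1-hydroxy-1-methylethyl on a triple-bonded carbon. Among the compounds with values here, no measured pair touches the alkyne terminus, so the step of a 6.9-fold lower number from compound 1 to compound 2 (0.84 log units; beyond the scatter) tells nothing about this change, and there is nothing to set the direction of the step from. The fluoro substituent that carried compound 2 to its lower number is retained in compound 3, so the starting point is that of compound 2.

Within the data shown here, with no bearing step available, the expectation for compound 3 is a number close to that of compound 2, with a range wide enough to admit a step in either direction: a 1.0-fold higher number from compound 2 to compound 3 (0.01 log units; within the scatter) is the estimated step. Compound 3 is estimated at 3 nM, with a range from 0.8 nM to 12 nM.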

Compound 3, inhibition constant: 0.4 nM
Estimate against measurement, compound 3: 7.5-fold (0.88 log units) above; the measured number lies below the stated range.
By their numbers in this assay, from the lowest: compound 3; then compound 2; then compound 1.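

The alkyne terminus is now shown to be a place where the series responds: in this assay, 1-hydroxy-1-(5-methyl-1,2-oxazol-3-yl)ethyl in place of 1-hydroxy-1-methylethyl on a triple-bonded carbon gives a 7.3-fold lower number from compound 2 to compound 3 (0.86 log units; beyond the scatter) and so extends the tertiary alcohol into a larger group, with one five-membered aromatic ring and one defined stereocentre, while the count of hydrogen-bond donors stays the same. Together with a 6.9-fold lower number from compound 1 to compound 2 (0.84 log units; beyond the scatter) in a different place, this gives two single changes on the shared core that each lower the number beyond the scatter, and compound 3 holds the lowest number of the three. Nothing available here bears on why the number falls with the new group.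

Open, as far as these compounds go, is whether a phenyl ring, a pyridine or a 1,2-oxazole without its methyl on the same carbon would give a comparable number, and whether the opposite configuration at the stereocentre would hold it. Also open, from the compounds shown here alone, is whether the new group would lower the number to the same degree on the core of compound 1, which lacks the fluoro.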